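Hydroxyacetyl in place of thienoyl on a benzofuran hydroxamic acid

The compounds below may be only part of what the source reports. "The series", "measured", "known", "first", "only" and "open" are said of these compounds alone.

Three hydroxamic acids have been measured in an assay on RBL cells for inhibition of Polyunsaturated fatty acid 5-lipoxygenase (Rattus norvegicus); on this read-out higher numbers stand for weaker inhibition and lower numbers for stronger inhibition. Compound 1, `CCCCCCCCCCc1cc2cc(C(C)N(O)C(C)=O)ccc2o1`, gives 410 nM. Compound 2, `COc1cccc(OC)c1C(=O)N(O)C(C)c1ccc2oc(-c3ccccc3)cc2c1`, gives 3000 nM. Compound 3, `CC(c1ccc2oc(-c3ccccc3)cc2c1)N(O)C(=O)c1cccs1`, gives 250 nM. Among the compounds with values here, the only single-point step among them is a 12-fold lower number from compound 2 to compound 3 (1.08 log units; beyond the scatter), so compound 3 sits well below compound 2, whereas the number for compound 1 lies within the scatter of that for compound 3. Compound 4, `CC(c1ccc2oc(-c3ccccc3)cc2c1)N(O)C(=O)CO`, differs from compound 3 by hydroxymethyl in place of thiophen-2-yl on a carbonyl carbon. Within the data shown here, the step from compound 2 to compound 3 shows that the group on the carbonyl carbon can move this assay strongly, but both of those groups are aromatic rings; no measured step replaces such a ring with a small open chain. Compound 1 carries an acetyl group on the same nitrogen yet a different substituent on the shared core, so its value of 410 nM gives only a loose hint that a small acyl group need not cost much. On that basis compound 4 is expected to show a 2.4-fold higher number from compound 3 to compound 4 (0.38 log units; beyond the scatter), a modest rise that may stay within the scatter. The estimate for compound 4 is 600 nM, with a range from 150 nM to 2500 nM.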

Compound 4, half-maximal inhibitory concentration: 700 nM
Compound 4: middle estimate off by 1.2-fold (0.07 log units), on the low side; the measured number falls inside the stated range.
By their numbers in this assay, from the lowest: compounds 3, 1 and 4 (each within the scatter of the next, the first and the last beyond it); then compound 2.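

Replacing thiophen-2-yl with hydroxymethyl on a carbonyl carbon gives a 2.8-fold higher number from compound 3 to compound 4 (0.45 log units; beyond the scatter) in this assay, so on this core the position still gives a sub-micromolar number with no ring on the carbonyl carbon, though the step is beyond the scatter. The same open group, set against 2,6-dimethoxyphenyl, gives a 4.3-fold lower number from compound 2 to compound 4 (0.63 log units; beyond the scatter) and so the presence of an aromatic ring does not by itself set the order here: one ring lies on the lower side of hydroxymethyl and the other on the higher side. No measured evidence shown here accounts for either step.

The compounds shown leave open whether the oxygen of hydroxymethyl contributes anything on this core, a question that a methyl, an aminomethyl or a longer alkyl chain on the same carbonyl carbon would address. They also leave open how an unsubstituted phenyl would read at this position, and with it whether the high number of compound 2 belongs to the two methoxy groups or to the ring that carries them.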